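The compounds below may be only part of what the source reports. "The series", "measured", "known", "first", "only" and "open" are said of these compounds alone.

Compound 1 `Cc1cccc(-n2nncc2CN2C(=O)C3(C(C#N)=C(N)Oc4c3c3nc5ccccc5nc3c3ccccc43)c3ccccc32)c1` gives in an ADME assay on L02 cells (Homo sapiens) for antiproliferative activity, read by MTT assay, with a stated time of 48 h (a higher number here means a weaker inhibitor, a lower number a stronger inhibitor), only a limit of the assay, > 50000 nM.
Compound 2 `N#CC1=C(N)Oc2c(c3nc4ccccc4nc3c3ccccc23)C12C(=O)N(Cc1cnnn1-c1ccccc1Cl)c1ccccc12` likewise gives only a limit, > 50000 nM.
Compound 3 `CC(=O)Nc1ccc(-n2nncc2CN2C(=O)C3(C(C#N)=C(N)Oc4c3c3nc5ccccc5nc3c3ccccc43)c3ccccc32)cc1` also gives only a limit, > 50000 nM.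

All three values rest at the limit of > 50000 nM in this assay, at which 3 of the 3 values shown sit, so compound 1 stands only at a limit, with no number of its own. Within the data shown here, the measured steps a step that the two limits leave unreadable from compound 1 to compound 2, a step that the two limits leave unreadable from compound 1 to compound 3 and a step that the two limits leave unreadable from compound 2 to compound 3 therefore cannot be read; they show only that each change kept the compound at the limit.

Compound 4 `N#CC1=C(N)Oc2c(c3nc4ccccc4nc3c3ccccc23)C12C(=O)N(Cc1cnnn1-c1cccc(S(N)(=O)=O)c1)c1ccccc12` differs from compound 1 by sulfamoyl in place of methyl on an aromatic carbon. Among the measured compounds shown here, no measured step touches the sulfamoyl, and none has a readable size, so the three limits offer no step to carry over in this assay. What they do show is that three different groups on the aromatic nitrogen all left the value at the limit.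

Compound 4 is expected to remain there, with an estimate of 60000 nM and a range from 30000 nM to 200000 nM. The expected step is a step that the limit leaves unreadable from compound 1 to compound 4, which is no change beyond the limit.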

Compound 4, half-maximal inhibitory concentration: > 50000 nM
Compound 4: a limit, no number; the forecaster's own chance of this, stated with the estimate: 85%; the middle value is on the limit's open side.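

Compound 4 also gives only a limit, so its steps from compound 1, compound 2 and compound 3 cannot be read: the limit of > 50000 nM in this assay, at which 4 of the 4 values shown sit.

From the compounds shown here alone, what stays open is the actual value of each of these four compounds in this assay, and whether any other group on the aromatic nitrogen would give a number there.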